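The compounds below may be only part of what the source reports. "The series", "measured", "known", "first", "only" and "open" are said of these compounds alone.

Compound 1 `CCSc1ccc([C@H](c2cc3cc(Br)ccc3nc2OC)[C@@](O)(CCN(C)C)c2cccc(F)c2)cn1` gives 30% in an ADME assay on the whole organism for pharmacokinetics, with Rattus norvegicus as the target (a lower number here means that a smaller share of the oral dose reaches the circulation, a higher number that a larger share of the oral dose reaches the circulation), the lower of the two numbers recorded so far in this series. Compound 2 `COc1nc2ccc(Br)cc2cc1[C@@H](c1ccnc(OC)c1OC)[C@@](O)(CCN(C)C)c1cccc(C#N)c1` differs from compound 1 in several places. In this assay compound 2 gives 68%, a gap beyond the usual scatter. Compound 3 `COc1nc2ccc(Br)cc2cc1[C@@H](c1cncc(C)c1)[C@@](O)(CCN(C)C)c1cccc(F)c1` is not yet measured; it differs from compound 1 by 5-methylpyridin-3-yl in place of 6-(ethylsulfanyl)pyridin-3-yl on a saturated chain carbon bound to an aromatic carbon and a saturated chain carbon. Going by the values given here, no measured pair covers this change, so the expectation rests on compound 1 alone: a modest rise, estimated as a number 10 percentage points higher from compound 1 to compound 3 (within the scatter), is expected but with wide uncertainty. For compound 3 the expected value in this assay is 40%, with a range from 18% to 65%.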

Compound 3, oral bioavailability: 24%
For compound 3 the middle estimate is 16 percentage points above the measured one; measured number inside the range.
By their numbers in this assay, from the lowest: compounds 3 and 1 (each within the scatter of the next); then compound 2.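

On the saturated chain carbon bound to an aromatic carbon and a saturated chain carbon, 5-methylpyridin-3-yl in place of 6-(ethylsulfanyl)pyridin-3-yl gives a number 6 percentage points lower from compound 1 to compound 3 (within the scatter) in this assay. This single-place change, which removes the sulfur and leaves one hydrogen-bond acceptor instead of two, therefore opens no gap beyond the scatter at this position. No measurement on hand offers an explanation for this result.

On these data alone, whether an amine or a carboxylic acid at this place would shift the read-out beyond the scatter remains open. So does whether the same step would hold on a different remainder of the molecule.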